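This account rests on a few compounds, and the source may have more. Where it says the series, first, only, none or still open, it means among the compounds named here.

Compound 2 `COc1ccccc1-n1c(Nc2nc(-c3ccc(Cl)cc3)cs2)n[nH]c1=S` carries a 2-methoxyphenyl group on an aromatic nitrogen of the shared core. Among the compounds with values here, in a functional assay on the whole organism (strain Swiss albino) for inhibition, with Mus musculus as the target, with a stated time of 4 h (a higher number here means that more compound is needed for the effect, a lower number that less compound is needed), compound 2 gives 100 mg/kg, which places it level with compound 1 `COc1ccc(-n2c(Nc3nc(-c4ccc(Cl)cc4)cs3)n[nH]c2=S)cc1`, the only other measured compound. In this assay compound 1 gives 100 mg/kg, and the step of no change at the digits printed from compound 1 to compound 2 (within the scatter) shows no change beyond the scatter. Compound 3 `Cc1ccc(-n2c(Nc3nc(-c4ccc(Cl)cc4)cs3)n[nH]c2=S)cc1` is the next compound to be measured. The change from compound 2 to compound 3 is 4-methylphenyl in place of 2-methoxyphenyl on an aromatic nitrogen. Within the data shown here, no measured step swaps a methoxy group for a methyl group, so nothing directly tests this change; the only measured step, no change at the digits printed from compound 1 to compound 2 (within the scatter), moves the methoxy group to another place on the phenyl ring and leaves the minimum effective dose unchanged. Since compound 1 and compound 2 sit at the same dose with the methoxy group in either place, the dose for compound 3 is expected to stay close to that of compound 2, with the expected step of no change at the digits printed from compound 2 to compound 3 (within the scatter) lying within the scatter. For compound 3 the estimated value in this assay is 100 mg/kg, with a range from 50 mg/kg to 200 mg/kg.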

Compound 3, minimum effective dose: 300 mg/kg
Estimate against measurement, compound 3: 3.0-fold (0.48 log units) below, and the stated range ends below it.
By their numbers in this assay, from the lowest: compounds 1 and 2 (each within the scatter of the next); then compound 3.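

The two methoxy compounds had shown only that the methoxy group could sit in either place on the phenyl ring without moving the minimum effective dose, whereas compound 3 shows that this dose does respond to what the ring carries. In this assay, exchanging methoxy for methyl on an aromatic carbon gives a 3.0-fold higher number from compound 1 to compound 3 (0.48 log units; beyond the scatter) and so isolates the change to that one group, while the exchange of 2-methoxyphenyl for 4-methylphenyl on the aromatic nitrogen gives a 3.0-fold higher number from compound 2 to compound 3 (0.48 log units; beyond the scatter) of the same size. Nothing shown here explains why the dose differs between the methyl and methoxy compounds.

The compounds shown leave open whether 2-methylphenyl would match 4-methylphenyl, as the two methoxy-bearing groups match each other. They also leave open whether a hydroxyl group, an amine or a longer alkoxy chain on the phenyl ring would stay level with the methoxy compounds or fall in with compound 3.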